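Lengthening the Amine Arm on a Pyrrolidine Side Chain

The source may hold more compounds than are shown below. What is called first, only, known or untested is meant among the compounds shown, and "the series" means these compounds.

Compounds measured so far:
compound 1 `COc1c(N2CC[C@@H](N)C2)c(F)cc2c(=O)c(C(=O)O)cn(Cc3ccc(-c4ccccc4)cc3)c12`: 92200 nM
compound 2 `O=C(O)c1cn(Cc2ccc(-c3ccccc3)cc2)c2cc(N3CC4CNCC4C3)c(F)cc2c1=O`: 33300 nM
compound 3 `O=C(O)c1cn(Cc2ccc(-n3cccn3)cc2)c2cc(NC[C@@H]3CCNC3)c(F)cc2c1=O`: 200000 nM

These three compounds were tested in an assay on isolated protein for inhibition of DNA topoisomerase 1 (Homo sapiens), with a stated time of 15 min; on this read-out higher numbers stand for weaker inhibition and lower numbers for stronger inhibition. Compound 3 gives the highest number of the three, 200000 nM, and compound 2 the lowest, 33300 nM. Compound 1 sits between them with 92200 nM; its gap to compound 3 and its gap to compound 2 both lie beyond the usual scatter of repeated runs, so compound 1 is genuinely weaker than compound 2 and stronger than compound 3 on this read-out. All three are weak inhibitors in absolute terms.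

Compound 4 `COc1c(N2CC[C@@H](CN)C2)c(F)cc2c(=O)c(C(=O)O)cn(Cc3ccc(-c4ccccc4)cc3)c12` has not yet been measured. It is compound 1 with one change: aminomethyl in place of amino on a saturated ring carbon. Among the measured compounds shown here, no pair of measured compounds differs by exactly this kind of change, so there is no measured step to lean on. For a change of this size on a side chain, with no sign in these data that it matters, the step from compound 1 to compound 4 is expected to be small, a 1.1-fold higher number from compound 1 to compound 4 (0.04 log units; within the scatter), and within the scatter. Compound 4 is therefore estimated at 100000 nM, with a plausible range from 40000 nM to 250000 nM.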

Compound 4, half-maximal inhibitory concentration: 26000 nM
The estimate for compound 4 lay 3.8-fold (0.59 log units) above the measured number; the measured number lies below the stated range.
By their numbers in this assay, from the lowest: compounds 4 and 2 (each within the scatter of the next); then compound 1; then compound 3.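

In this assay, among the compounds shown here, exchanging 3-aminopyrrolidin-1-yl for 3-(aminomethyl)pyrrolidin-1-yl gives a 3.5-fold lower number from compound 1 to compound 4 (0.55 log units; beyond the scatter), so this ring carbon of the side chain does respond to a small change, which the earlier compounds could not show because none of them formed a pair differing in one place. The counts of hydrogen-bond donors and acceptors and the net charge are the same for the leaving and entering groups, so the added carbon is the only counted difference, and the amine simply sits one carbon further out on the same ring position. Nothing available here bears on the cause of this step.

On these data alone, this is a single pair on the core of compound 1, so it remains open whether the same exchange would give a similar step on another core. A longer chain such as 2-aminoethyl on this ring carbon, or a methylamino group in place of the primary amine, would show whether the number keeps falling as the amine moves outward or depends on the amine itself.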